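A dichlorophenyl exchange on compound 2

This account rests on a few compounds, and the source may have more. Where it says the series, first, only, none or still open, it means among the compounds named here.

Compound 1 `COc1cc(/C=C2\CN(C)C/C(=C\c3ccc(Cl)c(Cl)c3)C2=O)cc(OC)c1` gives 3260 nM
Compound 2 `COc1cc(/C=C2\CN(C)C/C(=C\c3cc(OC)c(OC)c(OC)c3)C2=O)cc(OC)c1` gives 720 nM

In a functional assay on THP-1 cells (Homo sapiens) for cytotoxicity, read by MTT assay, with a stated time of 24 h (on this read-out higher numbers stand for weaker inhibition and lower numbers for stronger inhibition), compound 2 (720 nM) stands lowest of the two measured compounds, and compound 1 (3260 nM) gives a higher number, beyond the scatter. Compound 3 `COc1cc(/C=C2\CN(C)C/C(=C\c3ccc(Cl)c(Cl)c3)C2=O)cc(OC)c1OC` carries 3,4-dichlorophenyl in place of 3,5-dimethoxyphenyl on a double-bonded chain carbon bound to a double-bonded ring carbon. Among the measured compounds shown here, no measured step isolates this exchange. Compound 1 (3260 nM) also bears 3,4-dichlorophenyl, so a moderate rise in this assay toward weaker inhibition is expected, with an expected step (a 2.5-fold higher number from compound 2 to compound 3 (0.40 log units; beyond the scatter)) beyond the scatter. The estimated value for compound 3 is 1800 nM and is expected to lie from 650 nM to 5000 nM in repeat measurements.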

Compound 3, half-maximal inhibitory concentration: 5330 nM
Compound 3: middle estimate off by 3.0-fold (0.47 log units), on the low side; measured number outside the range, above it.
By their numbers in this assay, from the lowest: compound 2; then compounds 1 and 3 (each within the scatter of the next).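

With this assay as the read-out, the exchange of 3,5-dimethoxyphenyl for 3,4-dichlorophenyl on a double-bonded chain carbon bound to a double-bonded ring carbon can now be read directly (a 7.4-fold higher number from compound 2 to compound 3 (0.87 log units; beyond the scatter)), and it weakens inhibition. Methoxy in place of hydrogen on an aromatic carbon, by contrast, leaves no change that can be told from the scatter (a 1.6-fold higher number from compound 1 to compound 3 (0.21 log units; within the scatter)). No measurement shown here accounts for either step. On these data alone, what an amine or a carboxylic acid on the phenyl ring at this place would give remains open.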